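The source may report more compounds than this note shows. Statements on the series, on what has been measured and on what is new or still open speak of the compounds shown alone.

Two compounds of the series have numbers in an assay on cell membranes for displacement of a labelled ligand from adenosine receptor A1 (Bos taurus); on this read-out lower numbers stand for stronger inhibition and higher numbers for weaker inhibition. Compound 1 `CC(=O)Nc1nc(-c2ccccc2)nc2nc(C)cn12` gives 855 nM in this assay. Compound 2 `O=C(Nc1nc(-c2ccccc2)nc2nc(-c3ccccc3)cn12)C1CCCC1` gives 17 nM in this assay, the lower of the two numbers, and the gap to compound 1 lies beyond the scatter. Compound 1 and compound 2 differ in two places at once, so what the amide part alone contributes cannot be read from them. Compound 3 `CC(=O)Nc1nc(-c2ccccc2)nc2nc(-c3ccccc3)cn12` keeps the phenyl of compound 2 and alters only the amide: methyl in place of cyclopentyl on a carbonyl carbon. Among the compounds with values here, no step between measured compounds isolates this change. Because compound 1 gives 855 nM while carrying the same acetamido group, a weaker number is expected for compound 3, though part of the gap between compound 1 and compound 2 may come from the other difference between them. The expected step is a 4.7-fold higher number from compound 2 to compound 3 (0.67 log units; beyond the scatter), beyond the scatter. Compound 3 is expected at 80 nM, with a range of 25 nM to 300 nM.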

Compound 3, inhibition constant: 23 nM
Compound 3: the middle estimate sits 3.5-fold (0.54 log units) above what was measured; the measured number lies below the stated range.
By their numbers in this assay, from the lowest: compounds 2 and 3 (each within the scatter of the next); then compound 1.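

In this assay, methyl in place of cyclopentyl on a carbonyl carbon gives a 1.4-fold higher number from compound 2 to compound 3 (0.13 log units; within the scatter), so at this position the acetyl and cyclopentylcarbonyl forms cannot be told apart, and the small methyl serves as well as the five-membered ring of carbon. Phenyl in place of methyl on an aromatic carbon gives a 37-fold lower number from compound 1 to compound 3 (1.57 log units; beyond the scatter), which shows that the acetamido group does not by itself go with a weak number, and that of these two single changes only the one on the aromatic carbon moves the number beyond the scatter. No measurement at hand gives a reason for either step.

Still open, on these data alone, is whether this tolerance on the carbonyl carbon extends to a longer chain, an amine or a carboxylic acid. Also open, as far as these compounds go, is whether a substituted phenyl, such as chlorophenyl, on the aromatic carbon would hold the low number.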